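Hydroxy-nitrophenyl swap on a bromobenzylthio enone scaffold

This account rests on a few compounds, and the source may have more. Where it says the series, first, only, none or still open, it means among the compounds named here.

Measured compounds:
- compound 1, `O=C(/C(=C\c1ccc([N+](=O)[O-])c(O)c1)SCc1ccc(Br)cc1)c1ccc([N+](=O)[O-])cc1`: 1000 nM
- compound 2, `COc1cc(C(=O)/C(=C\c2ccc(O)c([N+](=O)[O-])c2)SCc2ccc(Br)cc2)cc(OC)c1OC`: 1000 nM
- compound 3, `O=C(/C(=C\c1ccc(O)c([N+](=O)[O-])c1)SCc1ccc(Br)cc1)c1ccc([N+](=O)[O-])cc1`: 10000 nM

The three measured compounds were tested in a functional assay on DU-145 cells (Homo sapiens) for inhibition, read by trypan blue exclusion, with a stated time of 96 h; on this read-out lower numbers stand for stronger inhibition of growth and higher numbers for weaker inhibition of growth. Compound 3 gives 10000 nM, while compound 1 gives 1000 nM and compound 2 gives 1000 nM. Compound 1 and compound 2 stand level at the digits reported, so no order can be read between them.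

Compound 1 and compound 3 share a core and differ in one place: 3-hydroxy-4-nitrophenyl in place of 4-hydroxy-3-nitrophenyl on a double-bonded chain carbon bound to a double-bonded chain carbon. This change produced a 10-fold lower number from compound 3 to compound 1 (1.00 log units; beyond the scatter). Compound 2 and compound 3 carry different cores; the difference between the two cores is not broken down here, and the two values only show that compound 2 sits where compound 1 does, well away from compound 3.

Compound 4, `COc1cc(C(=O)/C(=C\c2ccc([N+](=O)[O-])c(O)c2)SCc2ccc(Br)cc2)cc(OC)c1OC`, has not been measured in this assay. It relates to compound 2 by the same change that relates compound 3 to compound 1: 3-hydroxy-4-nitrophenyl in place of 4-hydroxy-3-nitrophenyl on a double-bonded chain carbon bound to a double-bonded chain carbon, made at the same place. On the core of compound 2 the change is being made from a starting number that is already level with compound 1, so it is uncertain whether the step repeats in full. Going by the values given here, compound 4 is therefore expected to show a 4.0-fold lower number from compound 2 to compound 4 (0.60 log units; beyond the scatter), a smaller step than the one from compound 3 to compound 1, because the only precedent is a 10-fold lower number from compound 3 to compound 1 (1.00 log units; beyond the scatter) and it was seen once. Compound 4 is estimated at 250 nM, within a range from 60 nM to 1000 nM.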

Compound 4, concentration for 50% growth inhibition: 1000 nM
Compound 4: middle estimate off by 4.0-fold (0.60 log units), on the low side; measured number inside the range.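

In this assay, putting 3-hydroxy-4-nitrophenyl in place of 4-hydroxy-3-nitrophenyl gave no change at the digits printed from compound 2 to compound 4 (within the scatter), so the gain seen on the core of compound 1 did not appear on the core of compound 2. Set side by side, the two results show that this change does not carry a fixed size from one core to the other in this series: the same change on two cores in this assay, a 10-fold lower number (1.00 log units; beyond the scatter) from compound 3 to compound 1 and no change at the digits printed (within the scatter) from compound 2 to compound 4, 10-fold (1.00 log units) apart, beyond the scatter of two such steps. This shows that the outcome of the swap differs between these two cores, but it does not show which feature of the cores sets that difference, and with a single pair on each core it gives no rule for how the swap would behave on a third core.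

All four compounds shown keep the bromobenzylthio part and carry both a hydroxy and a nitro group on the same phenyl ring, so they leave open how much of the activity depends on either group. As far as these compounds go, whether an amine or a carboxylic acid in place of the nitro group, or a chlorine in place of the bromine, would keep the numbers seen here also remains open.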